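The source may hold more compounds than are shown below. What is called first, only, known or untested is meant among the compounds shown, and "the series" means these compounds.

Three carbamates sharing one core have been tested in an ADME assay on 184B5 cells (Homo sapiens) for cytotoxicity, read by MTT assay, with a stated time of 72 h; on this read-out higher numbers stand for weaker inhibition of growth and lower numbers for stronger inhibition of growth. Compound 1 `CCCOC(=O)Nc1ccc([Se]C#N)cc1` gives 3700 nM in this assay. Compound 2 `CCCCOC(=O)Nc1ccc([Se]C#N)cc1` gives 5300 nM, and compound 3 `C=CCOC(=O)Nc1ccc([Se]C#N)cc1` gives 5000 nM. Compound 3 stands second highest of the three numbers: a 1.1-fold lower number from compound 2 to compound 3 (0.03 log units; within the scatter), and a 1.4-fold higher number from compound 1 to compound 3 (0.13 log units; within the scatter). All three numbers therefore sit within the usual spread of repeat measurements, and none of the three can be called more or less active than another.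

Compound 4 `N#C[Se]c1ccc(NC(=O)OCc2ccccc2)cc1` has not been measured. It differs from compound 3 in one place: phenyl in place of vinyl on a saturated chain carbon bound to an oxygen next to a carbonyl group. The steps already seen at this same position bear on it. a 1.4-fold higher number from compound 1 to compound 3 (0.13 log units; within the scatter) exchanged one small chain group for another, a 1.1-fold lower number from compound 2 to compound 3 (0.03 log units; within the scatter) did the same with a longer chain, and a 1.4-fold higher number from compound 1 to compound 2 (0.16 log units; within the scatter) lengthened the chain by one carbon. Every change tried at this position has left the number where it was. A phenyl brings a ring where none of the groups tried there had one, so the expectation rests on three flat steps alone. On that basis compound 4 is expected to give about 5000 nM in this assay, within a range of 2500 nM to 10000 nM. The estimated step is no change at the digits printed from compound 3 to compound 4 (within the scatter), nothing beyond the scatter.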

Compound 4, concentration for 50% growth inhibition: 5000 nM
The estimate for compound 4 equals the measured number at the digits printed; measured number inside the range.
By their numbers in this assay, from the lowest: compounds 1, 3, 4 and 2 (each within the scatter of the next).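

In this assay, among the compounds shown here, a ring stands at this position for the first time: phenyl replaces vinyl on a saturated chain carbon bound to an oxygen next to a carbonyl group, so six heavy atoms enter where two leave, yet the outcome is no change at the digits printed from compound 3 to compound 4 (within the scatter). Set against the saturated groups, the swap to phenyl gives a 1.1-fold lower number from compound 2 to compound 4 (0.03 log units; within the scatter) and a 1.4-fold higher number from compound 1 to compound 4 (0.13 log units; within the scatter), so no step among these groups lies beyond the scatter. The earlier compounds shown here showed this only for open chains, and compound 4 extends the flat picture to one aromatic ring of carbon only, though the claim holds for these four compounds alone.

Going by these compounds, all the groups compared here are built from carbon and hydrogen, so it stays open whether an amine or a carboxylic acid placed on the phenyl ring would move the number beyond the scatter. On these data alone, a much longer chain, or a ring joined directly to the oxygen without the saturated chain carbon, is equally open. Nothing measured here accounts for this flat behaviour.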